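Hydrazone aryl replacement: difluorophenyl to hydroxy-methoxyphenyl

The source may hold more compounds than are shown below. What is called first, only, known or untested is meant among the compounds shown, and "the series" means these compounds.

Of the compounds shown here, three have been measured in a functional assay on HT-29 cells (Homo sapiens) for cytotoxicity, read by MTT assay, with a stated time of 72 h; a lower number here means a stronger inhibitor, a higher number a weaker inhibitor. Compound 3 `CN(C)CCn1cnnc1-c1cc(Oc2ccc(NC(=O)N/N=C/c3ccc(F)cc3F)cc2F)ccn1` gives 960 nM, which places it second highest of the three numbers. Its nearest neighbour is compound 1 `CN(C)CCn1cnnc1-c1cc(Oc2ccc(NC(=O)N/N=C/c3cc(C(C)(C)C)cc(C(C)(C)C)c3O)cc2F)ccn1`, which in this assay gives 680 nM; the two lie within the scatter of each other. Going by the values given here, compound 2 `COc1ccc(/C=N/NC(=O)Nc2ccc(Oc3ccnc(-c4nncn4CCN(C)C)c3)c(F)c2)c(OC)c1OC` in this assay gives 3970 nM, the highest number of the set, and the only single-point step measured so far is a 4.1-fold lower number from compound 2 to compound 3 (0.62 log units; beyond the scatter).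

Compound 4 `COc1ccc(/C=N/NC(=O)Nc2ccc(Oc3ccnc(-c4nncn4CCN(C)C)c3)c(F)c2)cc1O` has not been measured. It differs from compound 3 in one place: 3-hydroxy-4-methoxyphenyl in place of 2,4-difluorophenyl on a carbon with a double bond to nitrogen. The step that bears on this is a 4.1-fold lower number from compound 2 to compound 3 (0.62 log units; beyond the scatter), where a 2,3,4-trimethoxyphenyl on the carbon with a double bond to nitrogen gave the weaker number. Compound 1 carries a hydroxy-bearing aryl at that carbon and sits within the scatter of compound 3. Among the compounds with values here, the entering 3-hydroxy-4-methoxyphenyl shares a methoxy with compound 2 and a hydroxy with compound 1, so a modest step toward a higher number is expected, smaller than the one seen for compound 2. The expected step is a 1.9-fold higher number from compound 3 to compound 4 (0.27 log units; within the scatter). For compound 4 the estimate in this assay is 1800 nM, with a range from 700 nM to 4500 nM.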

Compound 4, half-maximal inhibitory concentration: 960 nM
The estimate for compound 4 lay 1.9-fold (0.27 log units) above the measured number; measured number inside the range.
By their numbers in this assay, from the lowest: compounds 1, 3 and 4 (each within the scatter of the next); then compound 2.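

The exchange of 2,4-difluorophenyl for 3-hydroxy-4-methoxyphenyl on the carbon with a double bond to nitrogen gives no change at the digits printed from compound 3 to compound 4 (within the scatter) in this assay, so this position accepts a group with 1 hydrogen-bond donor and 2 hydrogen-bond acceptors in place of one with 0 of each, with no change outside the scatter. The step of a 4.1-fold lower number from compound 2 to compound 4 (0.62 log units; beyond the scatter) matches a 4.1-fold lower number from compound 2 to compound 3 (0.62 log units; beyond the scatter) in size, so an aryl with oxygen substituents does not by itself bring the higher number seen with 2,3,4-trimethoxyphenyl. Among these three single-place variants, that higher number stays with 2,3,4-trimethoxyphenyl alone, and fluorine on the aryl is not needed to hold the lower one.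

Nothing in hand gives a measured property of these groups that would account for the numbers.

The compounds shown do not separate the hydroxy from the methoxy of the entering group, since no phenyl carrying only one of them appears here. Also open, going by these compounds, is how an aryl bearing an amine or a carboxylic acid, or a saturated cyclohexyl in place of the aryl, would read in this assay.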